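The source may hold more compounds than are shown below. What is called first, only, known or untested is meant among the compounds shown, and "the series" means these compounds.

Measured so far:
Compound 1, `CCN1C(N(C)C)=Nc2ccccc2C1CC(=O)NCc1ccc([N+](=O)[O-])cc1`, gives 2170 nM in an assay on HEK293 cells for inhibition of Voltage-dependent T-type calcium channel subunit alpha-1G (Homo sapiens); on this read-out lower numbers stand for stronger inhibition and higher numbers for weaker inhibition.
Compound 2, `COC(=O)CC1c2ccccc2N=C(NCCCCCN)N1c1ccccc1`, gives 1840 nM in this assay.

Compound 2 has the lower of these two numbers, but compound 1 sits only a small distance away, within the scatter, so the two cannot be told apart on this read-out. Compound 3, `COC(=O)CC1c2ccccc2N=C(NCCCCCNC(=O)OC(C)(C)C)N1c1ccccc1`, has not yet been measured. It differs from compound 2 in one place: tert-butoxycarbonyl in place of hydrogen on an amine nitrogen. The free amine at the end of the chain is thus capped. For the measured compounds named here, no measured pair here shows how such a capping plays out, so the expectation rests on the structural change alone: a modest step toward a higher number in this assay, perhaps no further than the scatter. The expected step is a 1.6-fold higher number from compound 2 to compound 3 (0.21 log units; within the scatter). Compound 3 is expected to give about 3000 nM in this assay, within a range from 900 nM to 10000 nM.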

Compound 3, half-maximal inhibitory concentration: 2020 nM
The estimate for compound 3 lay 1.5-fold (0.17 log units) above the measured number; the range from low to high includes it.
By their numbers in this assay, from the lowest: compounds 2, 3 and 1 (each within the scatter of the next).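

Putting tert-butoxycarbonyl in place of hydrogen on an amine nitrogen gives a 1.1-fold higher number from compound 2 to compound 3 (0.04 log units; within the scatter) in this assay, so compound 2 and compound 3 cannot be told apart on this read-out. For this pair, the free amine is therefore not needed to keep the number in this range, and a group of this size is tolerated at this position. Nothing measured here gives a reason for this result.

From the compounds shown here alone, it remains open whether an acetyl group on the same nitrogen would read like tert-butoxycarbonyl. Going by these compounds, it is equally open whether a carboxylic acid in place of the amine, or a shorter or longer chain, would leave the number within the scatter or move it clearly beyond.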